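The source may hold more compounds than are shown below. What is called first, only, known or untested is meant among the compounds shown, and "the series" means these compounds.

Compound 2 `O=C(/C=C/c1ccc(O)c(O)c1)N1CCN(c2ccccc2Cl)CC1` is the point of departure. In a functional assay on B16-F10 cells (Mus musculus) for antiproliferative activity, read by MTT assay, with a stated time of 48 h (a lower number here means a stronger inhibitor, a higher number a weaker inhibitor), compound 2 gives 1.82 ug/mL. Going by the values given here, its only measured neighbour is compound 1 `O=C(/C=C/c1ccc(O)c(O)c1)N1CCN(c2ccccc2F)CC1`, which in this assay gives 2.43 ug/mL for compound 1. Among the compounds with values here, the single measured step, a 1.3-fold lower number from compound 1 to compound 2 (0.13 log units; within the scatter), lies within the scatter, so compound 2 has the lowest of the two numbers without being separable from compound 1. Compound 3 `CCN1CCN(C(=O)/C=C/c2ccc(O)c(O)c2)CC1` is not yet measured. It differs from compound 2 in one place: ethyl in place of 2-chlorophenyl on an amine nitrogen in a ring. Within the data shown here, no measured step bears on this change; the step known so far swaps one halogen for another on an aromatic carbon and leaves the amine nitrogen in a ring untouched, so the record gives no guide to the loss of the 2-chlorophenyl group in favour of ethyl. For this reason the account can only expect a step beyond the scatter in the direction of a higher number, with wide uncertainty, the step from compound 2 to compound 3 being estimated as a 3.3-fold higher number from compound 2 to compound 3 (0.52 log units; beyond the scatter). Compound 3 is therefore expected to give 6 ug/mL, in a range from 2 ug/mL to 20 ug/mL.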

Compound 3, half-maximal inhibitory concentration: 6.44 ug/mL
Compound 3: middle estimate off by 1.1-fold (0.03 log units), on the low side; measured number inside the range.
By their numbers in this assay, from the lowest: compounds 2 and 1 (each within the scatter of the next); then compound 3.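

In this assay the substituent on the amine nitrogen in a ring proves to be a place where the number moves beyond the scatter: ethyl in place of 2-chlorophenyl gives a 3.5-fold higher number from compound 2 to compound 3 (0.55 log units; beyond the scatter), and ethyl in place of 2-fluorophenyl gives a 2.7-fold higher number from compound 1 to compound 3 (0.42 log units; beyond the scatter). Exchanging the halogen on the aromatic carbon stayed within the scatter, whereas replacing the whole halogen-bearing aromatic ring with ethyl does not, although both new steps are modest and compound 3 still gives 6.44 ug/mL. No measurement bears on why the number rises with this change.

The compounds shown leave open whether the rise goes with losing the aromatic ring or with the shorter substituent, and a plain phenyl, a benzyl group or a longer alkyl chain on the same nitrogen would tell these apart. They also leave open how far the hydroxyl groups of the shared core matter, which a methoxy group in place of hydroxyl would test.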